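Dropping the methoxy group: a step from a limit

The source may hold more compounds than are shown below. What is called first, only, known or untested is meant among the compounds shown, and "the series" means these compounds.

The values below come from a functional assay on CCRF-CEM cells (Homo sapiens) for cytotoxicity, read by MTT assay, with a stated time of 72 h; on this read-out higher numbers stand for weaker inhibition of growth and lower numbers for stronger inhibition of growth.

Compound 1 `CSc1ccc(CNc2nc(SC)nc3ncccc23)cc1`: 16800 nM
Compound 2 `COc1ccc(CNc2nc(SC)nc3ncccc23)cc1`: > 100000 nM

Compound 2 has no number in this assay, only a limit; compound 2 sits at the limit of > 100000 nM in this assay, at which 1 of the 2 values shown sits. Where compound 2 carries methoxy, compound 1 carries methylsulfanyl, and compound 1 gives 16800 nM; the step of an at least 5.9-fold higher number from compound 1 to compound 2 (0.77 log units; beyond the scatter) is the only measured step here.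

The change now followed is hydrogen in place of methoxy on an aromatic carbon, which gives compound 3 `CSc1nc(NCc2ccccc2)c2cccnc2n1`. Among the compounds with values here, no measured step removes a group outright; the one step known exchanges methylsulfanyl for methoxy and points to weaker growth inhibition for the methoxy compound. Because compound 2 stands only at the limit of > 100000 nM in this assay, at which 1 of the 2 values shown sits, the size of the step to compound 3 cannot be read off, and the direction is open in both ways. Compound 3 is expected to land between the number for compound 1 and the limit of compound 2, with wide uncertainty, at about 50000 nM (range 12000 nM to 150000 nM). The step this estimate means is expected to be an at least 2.0-fold lower number from compound 2 to compound 3 (0.30 log units; that floor lies within the scatter).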

Compound 3, concentration for total growth inhibition: 98600 nM
Beside the measured number, compound 3's estimate is 2.0-fold (0.29 log units) below it; low and high end bracket the measured number.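

In this assay, hydrogen on this aromatic carbon, para to a large group, gives the series its first plain reference point, and exchanging methylsulfanyl for it gives a 5.9-fold higher number from compound 1 to compound 3 (0.77 log units; beyond the scatter). The earlier comparison set methylsulfanyl only against methoxy, whereas this one shows that the stronger growth inhibition of compound 1 holds against the bare position too, so it goes with the methylsulfanyl group itself and not merely with the absence of methoxy. Removing methoxy gives an at least 1.0-fold lower number from compound 2 to compound 3 (0.00 log units; that floor lies within the scatter), a floor that fixes no size and no direction, because that step starts from a limit and not from a number: the limit of > 100000 nM in this assay, at which 1 of the 3 values shown sits.

As far as these compounds go, whether methoxy differs from hydrogen at this place at all therefore stays open, and so does the question of whether it helps, harms or does nothing. The compounds shown also leave open whether the effect is particular to methylsulfanyl, or whether a longer sulfur chain such as ethylsulfanyl, a chlorine atom or an amine at the same place would do as well, better or worse.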